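Replacing a dimethylphenyl group with a naphthyl group

The source may hold more compounds than are shown below. What is called first, only, known or untested is meant among the compounds shown, and "the series" means these compounds.

Compound 2 `Cc1ccc(N2C(=O)[C@H]3[C@H](ON4[C@@H]3C(=O)N(C)[C@@]43C[C@H](C)CC[C@H]3C(C)C)C2=O)c(C)c1` stands at the top of the two measured numbers: in a functional assay, read by spectrophotometry, with a stated time of 2 h, tested at 2.5 mg/mL (on this read-out higher numbers stand for a stronger effect at the one concentration tested and lower numbers for a weaker effect), compound 2 gives 82.6%. Compound 1 `CC(C)[C@@H]1CC[C@@H](C)C[C@@]12N(C)C(=O)[C@@H]1[C@H]3C(=O)N(c4ccc(Cl)cc4)C(=O)[C@H]3ON12` differs from it only in the aryl group on the amide-type nitrogen, and in this assay compound 1 gives 60.1%. Within the data shown here, the one measured step is a number 22.5 percentage points higher from compound 1 to compound 2 (beyond the scatter), which shows that swapping the aryl group at this position can shift the read-out well beyond the scatter.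

Compound 3 `CC(C)[C@@H]1CC[C@@H](C)C[C@@]12N(C)C(=O)[C@@H]1[C@H]3C(=O)N(c4ccc5ccccc5c4)C(=O)[C@H]3ON12` takes this swap one step further: naphthalen-2-yl in place of 2,4-dimethylphenyl on an amide-type nitrogen in a ring. Among the measured compounds shown here, no measured pair involves a naphthalen-2-yl group, so the earlier step only indicates that the aryl group matters, not which way a larger one will move the number. Compound 3 is therefore expected to land somewhat below compound 2, a step of a number 10.6 percentage points lower from compound 2 to compound 3 (beyond the scatter), with a wide range. The estimate for compound 3 in this assay is 72%, between 45% and 95%.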

Compound 3, a percentage reported as activity, at one concentration (the size of the read-out at that concentration, not a potency): 47.9%
Beside the measured number, compound 3's estimate is 24.1 percentage points above it; the range from low to high includes it.
By their numbers in this assay, from the lowest: compound 3; then compound 1; then compound 2.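

Naphthalen-2-yl on this amide-type nitrogen moves the read-out down, and by more than the earlier aryl swap moved it: in this assay the change gives a number 34.7 percentage points lower from compound 2 to compound 3 (beyond the scatter). It also falls short of the 4-chlorophenyl group, with a number 12.2 percentage points lower from compound 1 to compound 3 (beyond the scatter), so compound 3 has the lowest number of the three, and the group with the most heavy atoms and two aromatic rings does not give the highest number here. Nothing available explains why this change lowers the number.

Three aryl groups cannot show whether the drop belongs to the second ring or to the loss of the two methyl groups, and an unsubstituted phenyl group would help separate these. Also open, on these data alone, is how naphthalen-1-yl, or a non-aromatic group such as cyclohexyl, would behave at this nitrogen.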